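The compounds below may be only part of what the source reports. "The series", "measured", "known", "first", "only" and "open" are said of these compounds alone.

Measured so far:
- compound 1, `Cc1nn(C)c2c1C(c1ccccc1Cl)=NCC(=O)N2` — in a functional assay on the whole organism with Rattus norvegicus as the target (a higher number here means that more compound is needed for the effect, a lower number that less compound is needed), compound 1 gives 16 mg/kg
- compound 2, `CCn1nc(C)c2c1NC(=O)CN=C2c1ccccc1Cl` — in this assay compound 2 gives 8 mg/kg

Among the compounds with values here, compound 2 stands at the lowest of the two numbers, yet its only neighbour is compound 1, and the step from compound 1 to compound 2 was a 2.0-fold lower number from compound 1 to compound 2 (0.30 log units; within the scatter), so the two values cannot be told apart with confidence. That step consisted of methyl in place of hydrogen on a saturated chain carbon bound to an aromatic nitrogen.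

Compound 3, `CCCn1nc(C)c2c1NC(=O)CN=C2c1ccccc1Cl`, has not yet been tested in this assay. It differs from compound 2 by methyl in place of hydrogen on a saturated chain carbon, two bonds along the chain from an aromatic nitrogen; read one bond further out, this is ethyl to propyl. Within the data shown here, the single comparable step, the one from compound 1 to compound 2, did not leave the scatter, so the expected step here is no change at the digits printed from compound 2 to compound 3 (within the scatter), that is, essentially none beyond the scatter. Compound 3 is therefore expected to give about 8 mg/kg, estimated to lie between 3 mg/kg and 20 mg/kg.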

Compound 3, minimum effective dose: 63 mg/kg
Estimate against measurement, compound 3: 7.9-fold (0.90 log units) below; measured number outside the range, above it.
By their numbers in this assay, from the lowest: compounds 2 and 1 (each within the scatter of the next); then compound 3.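

In this assay, within the data shown here, lengthening ethyl to propyl on the aromatic nitrogen gives a 7.9-fold higher number from compound 2 to compound 3 (0.90 log units; beyond the scatter), the first change at this position that stands clear of the scatter, since the earlier 2.0-fold lower number from compound 1 to compound 2 (0.30 log units; within the scatter) could not be told from noise. Compound 3 also needs more compound than the methyl-bearing compound 1, with a 3.9-fold higher number from compound 1 to compound 3 (0.60 log units; beyond the scatter), so the propyl chain sits apart from both shorter chains, whose own values cannot be separated; the same kind of change, one added methyl on a saturated chain carbon, thus had no readable effect in one place and a clear one a single bond further out. Nothing measured here explains why this added methyl matters when the previous one did not.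

Three chains are too few to show whether the rise in dose continues with a longer chain such as butyl or stops at propyl. Also open, as far as these compounds go, is how the position would respond to a branched group such as isopropyl, or to a chain ending in a hydroxyl group or an amine, rather than a plain straight chain.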